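Hydroxy to acetyl: what to expect next

A few compounds are considered here, and "the series" means these few. Any claim that something is new, unique, unknown or untested is made for them only; others in the source may bear on it.

Compound 1 `CC(=O)Oc1ccccc1C1CC(C)=NN1C(=O)CN(C(C)C)C(C)C`: 20100 nM
Compound 2 `CC(=O)Oc1ccccc1C1CC(C)=NN1C(=O)CN1CCC(O)CC1`: 3510 nM

Among the compounds with values here, in a functional assay on MGC-803 cells (Homo sapiens) for cytotoxicity, read by MTT assay, with a stated time of 48 h (a lower number here means a stronger inhibitor, a higher number a weaker inhibitor), compound 2 stands at 3510 nM and holds the lower of the two numbers so far, with compound 1 at 20100 nM as its only neighbour. Compound 3 `CC(=O)Oc1ccccc1C1CC(C)=NN1C(=O)CN1CCC(C(C)=O)CC1` keeps the shared core and differs from compound 2 at one place (acetyl in place of hydroxy on a saturated ring carbon), with acetyl in place of hydroxy on a saturated ring carbon. Within the data shown here, the sole measured step bearing on this is a 5.7-fold lower number from compound 1 to compound 2 (0.76 log units; beyond the scatter) and it brought in 4-hydroxypiperidin-1-yl in place of diisopropylamino. Among the measured compounds shown here, that step replaced the whole group, so it bears only indirectly, and no measured compound separates the hydroxy from the ring that carries it. Compound 2 sits at the low end with 3510 nM so far, so a small move towards a higher number in this assay is expected, smaller than the measured step and perhaps not beyond the scatter. The expected step is a 1.7-fold higher number from compound 2 to compound 3 (0.23 log units; within the scatter) in this estimate. For compound 3 the estimated value is 6000 nM (range 2000 nM to 18000 nM) when measured.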

Compound 3, half-maximal inhibitory concentration: 4120 nM
For compound 3 the middle estimate is 1.5-fold (0.16 log units) above the measured one; the measured number falls inside the stated range.
By their numbers in this assay, from the lowest: compounds 2 and 3 (each within the scatter of the next); then compound 1.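

In this assay, acetyl in place of hydroxy on this saturated ring carbon gives a 1.2-fold higher number from compound 2 to compound 3 (0.07 log units; within the scatter) and so leaves the reading within the scatter, although the group entering has 3 heavy atoms against 1 and 0 hydrogen-bond donors against 1. At this position, then, the hydroxy and its hydrogen-bond donor are not needed to hold the number at the level of compound 2, at least when acetyl takes their place. The advantage over the diisopropylamino compound also survives the change, with 4-acetylpiperidin-1-yl giving a 4.9-fold lower number from compound 1 to compound 3 (0.69 log units; beyond the scatter), so across these three compounds that advantage does not depend on the hydroxy alone. Nothing available explains why the two groups read alike.

The compounds shown still do not separate the contribution of the ring from that of the group it carries, since none has a plain piperidin-1-yl. Going by these compounds, whether a primary amine, a carboxylic acid or a longer chain such as butyl on the same ring carbon would also stay within the scatter of compound 2 remains open.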